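A few compounds are considered here, and "the series" means these few. Any claim that something is new, unique, unknown or untested is made for them only; others in the source may bear on it.

Of the compounds shown here, two sharing one core have been measured. Compound 1 `O=C1N/C(=N\c2nccs2)S/C1=C\c1cccc(O)c1` gives, in a functional assay on the whole organism (strain AKR) for inhibition, with Mus musculus as the target, read by paw edema, with a stated time of 3.5 h, at a dose of 0.01 mmol/kg by the intraperitoneal route (a higher number here means more inhibition at the dose given (going by the name of the read-out), a lower number less inhibition), 33.7%. Compound 2 `O=C1N/C(=N\c2nccs2)S/C1=C\c1cccc(Br)c1` gives in this assay 42.7%. Within the data shown here, these are the only two numbers so far, and compound 2 stands at the upper of them, though the step of a number 9 percentage points higher from compound 1 to compound 2 (within the scatter) lies within the scatter, so the two compounds cannot be separated on this evidence.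

Compound 3 `O=C1N/C(=N\c2nccs2)S/C1=C\c1cc(Br)ccc1O` differs from compound 2 by a single change, (hydroxy in place of hydrogen on an aromatic carbon). Among the measured compounds shown here, the only measured step that touches a hydroxy group is the one from compound 1 to compound 2, where a bromo replaced a hydroxy on an aromatic carbon, and that step was not larger than the scatter. For the measured compounds named here, there is no measured pair in which a hydroxy is added while the bromo is kept, so the bearing of that step on compound 3 is indirect.

On this basis no step beyond the scatter is expected in this assay for compound 3, which is estimated at 38% with a range of 20% to 56%, corresponding to an expected step of a number 4.7 percentage points lower from compound 2 to compound 3 (within the scatter).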

Compound 3, a percentage reported as inhibition, in the whole organism at one dose (the size of the read-out at that dose, not a potency): 54.4%
Compound 3: middle estimate off by 16.4 percentage points, on the low side, and the stated range covers the measured number.
By their numbers in this assay, from the lowest: compounds 1 and 2 (each within the scatter of the next); then compound 3.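

Adding a hydroxy on the aromatic carbon ortho to a large group and para to a bromo group, with the bromo kept, gives in this assay a number 11.7 percentage points higher from compound 2 to compound 3 (beyond the scatter), a modest step but the first one here that lies beyond the scatter. Among these compounds, the only earlier step, an exchange of a hydroxy for a bromo on an aromatic carbon, was a number 9 percentage points higher from compound 1 to compound 2 (within the scatter), so it could not show whether changes on this ring register in the read-out at all, whereas this position responds to the added group when the bromo stays in place. Nothing measured for these compounds bears on why the hydroxy has this effect.

The compounds shown leave open whether a methoxy group or an amine on the same aromatic carbon would match the hydroxy, and whether a chloro group could stand in for the bromo. They also leave open whether the hydroxy would give a similar step with no bromo on the ring, and, as each number is the size of the read-out at one dose, how the step would look at other doses.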